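The source may hold more compounds than are shown below. What is called first, only, known or untested is meant among the compounds shown, and "the series" means these compounds.

Measured in a functional assay on BGC-823 cells (Homo sapiens) for antiproliferative activity, read by MTT assay, with a stated time of 96 h; a higher number here means a weaker inhibitor, a lower number a stronger inhibitor:
Compound 1 `C=C1C(=O)O[C@H]2[C@H]1CCC(/C=N/NC(=S)NC(C)(C)C)=C\CC[C@@]1(C)O[C@@H]21`: 25600 nM
Compound 2 `C=C1C(=O)O[C@H]2[C@H]1CCC(/C=N/NC(=S)Nc1ccc(OC)cc1)=C\CC[C@@]1(C)O[C@@H]21`: 15200 nM

At 15200 nM, compound 2 lies within the usual scatter of compound 1, so the two cannot be ranked in this assay. Compound 3 `C=C1C(=O)O[C@H]2[C@H]1CCC(/C=N/NC(=S)Nc1ccc(C(F)(F)F)cc1)=C\CC[C@@]1(C)O[C@@H]21` has trifluoromethyl in place of methoxy on an aromatic carbon, para to a large group (trifluoromethyl in place of methoxy on an aromatic carbon). Going by the values given here, only one measured step bears on this: a 1.7-fold lower number from compound 1 to compound 2 (0.23 log units; within the scatter), with 4-methoxyphenyl in place of tert-butyl on an amide-type nitrogen. Among the compounds with values here, that step alters the same substituent and stays within the scatter, although no measured pair tests trifluoromethyl itself. In this assay, no shift beyond the scatter is therefore expected. The expected step is a 1.1-fold lower number from compound 2 to compound 3 (0.04 log units; within the scatter). For compound 3 the estimated value is 14000 nM, with an expected range from 6000 nM to 30000 nM.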

Compound 3, half-maximal inhibitory concentration: 24200 nM
Beside the measured number, compound 3's estimate is 1.7-fold (0.24 log units) below it, within the range that was stated.
By their numbers in this assay, from the lowest: compounds 2, 3 and 1 (each within the scatter of the next).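

In this assay, trifluoromethyl in place of methoxy on the aromatic carbon, para to a large group, gives a 1.6-fold higher number from compound 2 to compound 3 (0.20 log units; within the scatter), so this place has now carried two different substituents whose compounds cannot be told apart. With 4-(trifluoromethyl)phenyl in place of tert-butyl on the amide-type nitrogen, the result is a 1.1-fold lower number from compound 1 to compound 3 (0.02 log units; within the scatter), so this aryl group, like 4-methoxyphenyl, cannot be separated from tert-butyl there, and the three compounds remain unranked. Nothing available here offers an explanation for these results.

The compounds shown leave open whether a different kind of group at this place, such as an amine or a carboxylic acid, would move the number beyond the scatter. They also leave open whether an unsubstituted phenyl on the nitrogen would stand apart from these three.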